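The compounds below may be only part of what the source reports. "The series", "measured", "known", "first", "only" and "open" are said of these compounds alone.

In a functional assay on A549 cells (Homo sapiens) for inhibition, read by MTT assay, with a stated time of 48 h (on this read-out higher numbers stand for weaker inhibition and lower numbers for stronger inhibition), compound 1 `COc1cccc(NC(=O)/C=C/c2coc3cc(OC)ccc3c2=O)c1` gives 12800 nM and compound 2 `COc1ccc(NC(=O)/C=C/c2coc3cc(OC)ccc3c2=O)cc1` gives 23000 nM, and the step of a 1.8-fold higher number from compound 1 to compound 2 (0.25 log units; within the scatter) stays within the scatter. Compound 3 `COc1ccc2c(=O)c(/C=C/C(=O)Nc3ccccc3OC)coc2c1` reaches only the limit of this assay and is reported as > 100000 nM, which is the limit of > 100000 nM in this assay, at which 1 of the 3 values shown sits. The steps of an at least 7.8-fold higher number from compound 1 to compound 3 (0.89 log units; beyond the scatter) and an at least 4.3-fold higher number from compound 2 to compound 3 (0.63 log units; beyond the scatter) both lie beyond the scatter. Compound 4 `COc1ccc2c(=O)c(/C=C/C(=O)Nc3ccccc3C)coc2c1` differs from compound 3 by methyl in place of methoxy on an aromatic carbon. Going by the values given here, none of the measured steps covers this change, and the two steps into compound 3 end at a limit. The step of a number no higher from compound 3 to compound 4 (the limit leaves the size open) is therefore expected to be small and uncertain in direction. Compound 4 is estimated at 100000 nM in this assay, within 30000 nM to 300000 nM.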

Compound 4, half-maximal inhibitory concentration: 23400 nM
Estimate against measurement, compound 4: 4.3-fold (0.63 log units) above; the measured number lies below the stated range.
By their numbers in this assay, from the lowest: compounds 1, 2 and 4 (each within the scatter of the next). At a limit, above all of these: compound 3.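

With 2-methylphenyl in place of 2-methoxyphenyl, the reading is an at least 4.2-fold lower number from compound 3 to compound 4 (0.63 log units; beyond the scatter), so a group ortho to a large group does not by itself carry the loss seen in compound 3. Compound 4 cannot be told apart from the 4-methoxyphenyl and 3-methoxyphenyl amides, with a 1.0-fold higher number from compound 2 to compound 4 (0.01 log units; within the scatter) and a 1.8-fold higher number from compound 1 to compound 4 (0.26 log units; within the scatter) as the readings. From the compounds shown here alone, the value of compound 3 is a limit, so the size of the first step stays open: the limit of > 100000 nM in this assay, at which 1 of the 4 values shown sits.

Open, going by these compounds, is whether a hydroxy group or an amine in this place reads like methyl or like methoxy. Also open, on these data alone, is how 3-methylphenyl and 4-methylphenyl amides compare with compound 4.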